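Moving the chlorine around the phenoxy tail

A few compounds are considered here, and "the series" means these few. Any claim that something is new, unique, unknown or untested is made for them only; others in the source may bear on it.

The measured compounds:
compound 1, `NC1=NC2(CCOCC2)N(OCCCOc2ccc(Cl)cc2)C(N)=N1` — "not determined" (no result reported)
compound 2, `NC1=NC2(CCSCC2)N(OCCCOc2ccccc2Cl)C(N)=N1` — 80 nM

Compound 1 carries a 4-chlorophenoxy group on a three-carbon chain attached through oxygen to the shared core. In a functional assay on HepG2 cells (Homo sapiens) for antiproliferative activity, read by MTT assay, with a stated time of 72 h (on this read-out higher numbers stand for weaker inhibition and lower numbers for stronger inhibition), compound 1 gives "not determined" (no result reported), so no number exists for where it stands; it is a structure without a result. Compound 2 differs from compound 1 in more than one place, with a sulfur-containing ring and a 2-chlorophenoxy tail, and in this assay compound 2 gives 80 nM. That single number is the only anchor in this series.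

Compound 3, `NC1=NC2(CCOCC2)N(OCCCOc2cccc(Cl)c2)C(N)=N1`, is compound 1 with 3-chlorophenyl in place of 4-chlorophenyl on an oxygen on a saturated carbon. Within the data shown here, with no value for compound 1, no measured step can be drawn, and the expected step in this assay is none beyond the usual scatter: the same atoms are present, only joined differently, and nothing in the data points in either direction.

Compound 3 is therefore expected to fall near 150 nM, with a range from 40 nM to 600 nM, because compound 2 gives 80 nM as the only related result and so sets the scale for this family in this assay.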

Compound 3, half-maximal inhibitory concentration: 150 nM
Compound 3: the middle estimate sits on the measured number at the digits printed; the range from low to high includes it.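

In this assay compound 3 gives 150 nM and compound 1 gives "not determined" (no result reported); no step can be read between these two compounds. From the compounds shown here alone, whether 4-chlorophenoxy and 3-chlorophenoxy on the shared core differ on this read-out stays open. No evidence at hand bears on the result of compound 3.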